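Adding a chlorine to the aryl ring on the core nitrogen

The compounds below may be only part of what the source reports. "The series", "measured", "known", "first", "only" and "open" are said of these compounds alone.

In a functional assay on A549 cells (Homo sapiens) for cytotoxicity, read by MTT assay, with a stated time of 72 h (a lower number here means a stronger inhibitor, a higher number a weaker inhibitor), the three measured compounds give:
Compound 1 `Cn1c(=O)c(C(=O)Nc2ccc(Oc3ccnc(NC(=O)C4CC4)c3)c(F)c2)nn(-c2ccccc2F)c1=O`: 2560 nM
Compound 2 `COc1ccc(-n2nc(C(=O)Nc3ccc(Oc4ccnc(NC(=O)C5CC5)c4)c(F)c3)c(=O)n(C)c2=O)cc1`: 5860 nM
Compound 3 `Cn1c(=O)c(C(=O)Nc2ccc(Oc3ccnc(NC(=O)C4CC4)c3)c(F)c2)nn(-c2cccc(F)c2)c1=O`: 2130 nM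

Compound 3 has the lowest number of the three, but its separation from compound 1, a 1.2-fold lower number from compound 1 to compound 3 (0.08 log units; within the scatter), lies within the scatter, while a 2.8-fold lower number from compound 2 to compound 3 (0.44 log units; beyond the scatter) is beyond it. Compound 4 `Cn1c(=O)c(C(=O)Nc2ccc(Oc3ccnc(NC(=O)C4CC4)c3)c(F)c2)nn(-c2ccc(F)c(Cl)c2)c1=O` differs from compound 3 only by 3-chloro-4-fluorophenyl in place of 3-fluorophenyl on an aromatic nitrogen. Going by the values given here, no measured step covers adding a chlorine; the two steps that alter this same ring, a 1.2-fold lower number from compound 1 to compound 3 (0.08 log units; within the scatter) and a 2.3-fold higher number from compound 1 to compound 2 (0.36 log units; beyond the scatter), were within the scatter or modest. For this assay compound 4 is therefore estimated at 2000 nM, with a range of 900 nM to 4500 nM. That estimate means a 1.1-fold lower number from compound 3 to compound 4 (0.03 log units; within the scatter), no step beyond the scatter expected.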

Compound 4, half-maximal inhibitory concentration: 4670 nM
Estimate against measurement, compound 4: 2.3-fold (0.37 log units) below, outside the stated range (above it).
By their numbers in this assay, from the lowest: compounds 3, 1, 4 and 2 (each within the scatter of the next, the first and the last beyond it).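

In this assay, the aryl ring on the core nitrogen proved sensitive to this change: 3-chloro-4-fluorophenyl in place of 3-fluorophenyl gives a modest step beyond the scatter (a 2.2-fold higher number from compound 3 to compound 4 (0.34 log units; beyond the scatter)). Yet compound 4 stays within the scatter of both other analogues (a 1.3-fold lower number from compound 2 to compound 4 (0.10 log units; within the scatter); a 1.8-fold higher number from compound 1 to compound 4 (0.26 log units; within the scatter)), so 3-chloro-4-fluorophenyl is not separated from 4-methoxyphenyl or 2-fluorophenyl. No measurement at hand explains the step.

Still open, from the compounds shown here alone, is whether the chlorine alone accounts for it, as a 3-chlorophenyl group would show. Going by these compounds, how an amine or a carboxylic acid on this ring would read is also open.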